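The source may report more compounds than this note shows. Statements on the series, on what has been measured and on what is new or still open speak of the compounds shown alone.

Compound 1 `Cc1cc(N2CC[C@@H](C)[C@@H](N(C)c3ncnc4[nH]ccc34)C2)n2nc(SCc3ccc(F)cc3)nc2n1`, compound 2 `Cc1ccc(CSc2nc3nc(C)cc(N4CC[C@@H](C)[C@@H](N(C)c5ncnc6[nH]ccc56)C4)n3n2)cc1` and compound 3 `Cc1cc(N2CC[C@@H](C)[C@@H](N(C)c3ncnc4[nH]ccc34)C2)n2nc(SCc3ccc(Br)cc3)nc2n1` share one core and differ by a single substituent on an aromatic carbon. In a toxicity assay on GES1 cells (Homo sapiens) for inhibition, read by MTT assay, with a stated time of 72 h (on this read-out higher numbers stand for weaker inhibition and lower numbers for stronger inhibition), compound 1 gives 12300 nM, compound 2 gives 82500 nM and compound 3 gives 55600 nM. Compound 3 therefore stands among the higher numbers of the three, with a 1.5-fold lower number from compound 2 to compound 3 (0.17 log units; within the scatter) at its near side and a 4.5-fold higher number from compound 1 to compound 3 (0.66 log units; beyond the scatter) at its far side.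

Compound 4 `Cc1cc(N2CC[C@@H](C)[C@@H](N(C)c3ncnc4[nH]ccc34)C2)n2nc(SCCCc3ccccc3)nc2n1` departs from compound 3 by phenethyl in place of 4-bromophenyl on a saturated chain carbon bound to a sulfur. The same change reads as 4-bromobenzyl to 3-phenylpropyl. Going by the values given here, no measured step alters this chain, so the evidence is only indirect. The aromatic substituent steps were modest, with a 6.7-fold higher number from compound 1 to compound 2 (0.83 log units; beyond the scatter) alongside the step from fluoro to bromo already given. No step beyond the scatter is therefore expected, and any shift would more likely be toward a lower number. The expected change is a 1.6-fold lower number from compound 3 to compound 4 (0.20 log units; within the scatter).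

The estimate for compound 4 is 35000 nM, with an expected range from 10000 nM to 110000 nM.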

Compound 4, half-maximal inhibitory concentration: > 100000 nM
Compound 4: no number, only a limit (the forecaster's own chance of this, stated with the estimate: 10%); at least 2.8-fold (0.45 log units) between middle value and limit.
By their numbers in this assay, from the lowest: compound 1; then compounds 3 and 2 (each within the scatter of the next). At a limit, above all of these: compound 4.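

In this assay, compound 4 gives only a limit of the assay, not a number: the limit of > 100000 nM in this assay, at which 1 of the 4 values shown sits. This is the first change shown on the saturated chain carbon bound to a sulfur rather than on the aromatic ring, and the comparison with the 4-fluorobenzyl compound is the only one that clearly separates, with an at least 8.1-fold higher number from compound 1 to compound 4 (0.91 log units; beyond the scatter). Against the other two compounds, the floors settle no order, with an at least 1.7-fold higher number from compound 3 to compound 4 (0.25 log units; that floor lies within the scatter) and an at least 1.2-fold higher number from compound 2 to compound 4 (0.08 log units; that floor lies within the scatter).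

The move from 4-bromobenzyl to 3-phenylpropyl alters the chain and removes the ring substituent together, so the compounds shown cannot separate the two changes, and how far compound 4 lies past the limit stays unknown. They also leave open how an unsubstituted benzyl group, a longer chain or an amine would read at this place.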